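Para-substituent swap on an anilide fumaramide series

This account rests on a few compounds, and the source may have more. Where it says the series, first, only, none or still open, it means among the compounds named here.

Measured so far in a functional assay on Molt4/C8 cells (Homo sapiens) for cytotoxicity; on this read-out lower numbers stand for stronger inhibition and higher numbers for weaker inhibition:
Compound 1 `Cc1cccc(C)c1NC(=O)/C=C/C(=O)N1C/C(=C\c2ccccc2)C(=O)/C(=C/c2ccccc2)C1` gives 6600 nM.
Compound 2 `COc1ccc(NC(=O)/C=C/C(=O)N2C/C(=C\c3ccccc3)C(=O)/C(=C/c3ccccc3)C2)cc1` gives 1100 nM.

Among the measured compounds shown here, of the two numbers available, compound 2 holds the lower one, and the only measured step, a 6.0-fold lower number from compound 1 to compound 2 (0.78 log units; beyond the scatter), concerns the aryl group on the amide-type nitrogen. Compound 3 `O=C(/C=C/C(=O)N1C/C(=C\c2ccccc2)C(=O)/C(=C/c2ccccc2)C1)Nc1ccc(Cl)cc1` keeps everything in compound 2 except that (chloro in place of methoxy on an aromatic carbon), so that 4-methoxyphenyl becomes 4-chlorophenyl. For the measured compounds named here, no measured step exchanges one para substituent for another; the step from compound 1 to compound 2 moved two methyl groups away from that ring and a methoxy group onto it, which is a different change, so it only sets the scale of what this ring can do in this assay. Going by the values given here, with no directly comparable step, the expectation for compound 3 is a number close to compound 2, with the step of a 1.1-fold higher number from compound 2 to compound 3 (0.04 log units; within the scatter) expected to lie within the scatter. The estimate for compound 3 is therefore 1200 nM, within a range from 400 nM to 4000 nM.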

Compound 3, half-maximal inhibitory concentration: 1800 nM
Estimate against measurement, compound 3: 1.5-fold (0.18 log units) below, within the range that was stated.
By their numbers in this assay, from the lowest: compounds 2 and 3 (each within the scatter of the next); then compound 1.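

In this assay, among the compounds shown here, this is the first direct exchange of one group for another at this ring position, and a 1.6-fold higher number from compound 2 to compound 3 (0.21 log units; within the scatter) shows that methoxy and chloro cannot be told apart here. Replacing 2,6-dimethylphenyl with 4-chlorophenyl gives a 3.7-fold lower number from compound 1 to compound 3 (0.56 log units; beyond the scatter), so both phenyl rings carrying one substituent para to a large group now stand apart from the 2,6-dimethylphenyl ring of compound 1. No separate data bear on the reason for either step.

As far as these compounds go, what an amine, a carboxylic acid or a trifluoromethyl group would do at this same position remains open. Also open, from the compounds shown here alone, is whether a ring with no substituent at all would match compound 2 and compound 3, which would show whether this position needs a group.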